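The compounds below may be only part of what the source reports. "The series", "measured", "known", "first", "only" and "open" are said of these compounds alone.

compound 1 `O=C(Nc1cccc(Cl)c1)Nc1ccc(-c2cc(=O)c3ccccc3o2)c(Cl)c1`: 9700 nM
compound 2 `COc1ccc2oc(-c3ccc(NC(=O)Nc4ccc(Cl)c(Cl)c4)cc3Cl)cc(=O)c2c1`: 9900 nM

Both values come from a functional assay on HepG2 cells (Homo sapiens) for inhibition, read by MTT assay, with a stated time of 48 h; on this read-out higher numbers stand for weaker inhibition and lower numbers for stronger inhibition. Compound 1 has the lower number of the two, but compound 2 lies within the usual scatter of it, so compound 1 stands level with compound 2. Compound 3 `O=C(Nc1cccc(Cl)c1)Nc1ccc(-c2cc(=O)c3cc(F)ccc3o2)c(Cl)c1` is compound 1 with one change, fluoro in place of hydrogen on an aromatic carbon. Going by the values given here, no measured pair shows this change alone, so no step beyond the scatter is expected in this assay. The estimate is a 1.2-fold lower number from compound 1 to compound 3 (0.08 log units; within the scatter), which stays within the scatter. Compound 3 is expected at 8000 nM, with an estimated range from 3500 nM to 18000 nM.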

Compound 3, half-maximal inhibitory concentration: 31700 nM
For compound 3 the middle estimate is 4.0-fold (0.60 log units) below the measured one; the whole stated range lies below it.
By their numbers in this assay, from the lowest: compounds 1 and 2 (each within the scatter of the next); then compound 3.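

In this assay, putting a single fluoro in place of hydrogen on this aromatic carbon gives a 3.3-fold higher number from compound 1 to compound 3 (0.51 log units; beyond the scatter), which means weaker inhibition. Going by these compounds alone, this position is therefore sensitive to a change of just one atom, something no earlier pair could show, since no measured compounds had differed in this one place alone. Nothing available explains this step. Going by these compounds, whether a nitrile or an amine on the same carbon would also weaken inhibition remains open. So does whether fluoro on another carbon of this ring would give a similar step.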